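Ring configuration in a diterpene glycoside series

The source may report more compounds than this note shows. Statements on the series, on what has been measured and on what is new or still open speak of the compounds shown alone.

Measured compounds:
compound 1 `C=C[C@@](C)(CC[C@H]1C(C)=CC[C@H]2C(C)(C)CCC[C@]12C)O[C@@H]1O[C@@H](C)[C@@H](O)[C@H](O)[C@H]1O`: 3.9 ug/mL
compound 2 `C=C[C@@](C)(CC[C@@H]1[C@@]2(C)CCCC(C)(C)[C@@H]2CC[C@@]1(C)O)O[C@H]1O[C@H](C)[C@H](O)[C@@H](O)[C@@H]1O`: > 5 ug/mL

In a functional assay on A549 cells (Homo sapiens) for cytotoxicity, read by sulforhodamine B assay (a higher number here means that more compound is needed for the effect, a lower number that less compound is needed), compound 1 gives 3.9 ug/mL. Compound 2 gives only a limit of this assay, > 5 ug/mL, not a number. Compound 2 therefore stands at the limit of > 5 ug/mL in this assay, at which 1 of the 2 values shown sits. For the measured compounds named here, no step between compound 1 and compound 2 is given, so their two values are left to speak for themselves.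

Compound 3 `C=C[C@@](C)(CC[C@@H]1[C@@]2(C)CCCC(C)(C)[C@@H]2CC[C@@]1(C)O)O[C@@H]1O[C@H](C)[C@H](O)[C@H](O)[C@H]1O` has not been measured. It differs from compound 2 as follows: the two compounds have the same atoms and bonds and differ only in configuration as drawn: 3 of 10 stereo elements differ; a stereocentre at a saturated ring carbon is drawn R in compound 2 and S in compound 3; a stereocentre at a saturated ring carbon is drawn R in compound 2 and S in compound 3; a stereocentre at a saturated ring carbon is drawn S in compound 2 and R in compound 3. Only ring configuration changes; atoms and bonds are the same.

Since compound 2 sits at a limit, no step beyond the usual scatter is expected from compound 2 to compound 3; the expected step is a step that the limit leaves unreadable from compound 2 to compound 3. Compound 3 is estimated at 6 ug/mL in this assay, with a range from 2.5 ug/mL to 15 ug/mL, and a limit is the most likely outcome.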

Compound 3, concentration for half-maximal effect: > 5 ug/mL
Compound 3 ended at the assay's limit; the forecaster's own chance of this, stated with the estimate: 60%; the middle value does not contradict the limit.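

In this assay compound 3 gives > 5 ug/mL, a limit and not a number. For the compounds shown here, compound 2 also sits at a limit, so no step between compound 2 and compound 3 can be read. The compounds shown leave open whether this change in ring configuration shifts the value in this assay at all.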